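The source may report more compounds than this note shows. Statements on the series, on what has been measured and on what is new or still open speak of the compounds shown alone.

Measured compounds in an ADME assay on MDBK cells (Bos taurus) for cytotoxicity, read by MTT assay, with a stated time of 96 h; a lower number here means that less compound is tolerated, a higher number that more compound is tolerated:

Compound 1 `CN1CCN(CC(=O)Nc2ccc(-c3nc4cc(Cl)c(Cl)cc4[nH]3)cc2)CC1`: 90000 nM
Compound 2 `Cn1c(-c2ccc([N+](=O)[O-])cc2)nc2cc(C(F)(F)F)ccc21`: a limit of the assay, > 100000 nM
Compound 3 `COc1cc(OC)cc(-c2nc3cc(C(F)(F)F)ccc3[nH]2)c1`: a limit of the assay, > 100000 nM

Compound 1 is the only one of the three that gives an actual number in this assay, and that number, 90000 nM, lies close to the edge of what the assay reports. For compound 2 the assay gives only a limit, > 100000 nM. For compound 3 likewise only a limit is known, > 100000 nM. So the shared core is tolerated up to high concentrations by these cells, and compound 1 stands near the limit of > 100000 nM in this assay, at which 2 of the 3 values shown sit, rather than clearly apart from it.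

The next compound, compound 4 `CC(=O)Nc1ccc(-c2nc3cc(Cl)c(Cl)cc3[nH]2)cc1`, differs from compound 1 in one place: hydrogen in place of 4-methylpiperazin-1-yl on a saturated chain carbon bound to a carbonyl carbon. Among the compounds with values here, no measured pair shows what such a change does in this assay, so nothing in the data points to a direction. Because compound 1 already sits close to the limit of > 100000 nM in this assay, at which 2 of the 3 values shown sit, the step is expected to be small, within the scatter, or to end at the limit itself.

Compound 4 is therefore expected at 100000 nM, in the range 35000 nM to 300000 nM, and the expected step is a 1.1-fold higher number from compound 1 to compound 4 (0.05 log units; within the scatter), with a fair chance that only a limit is reported.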

Compound 4, half-maximal cytotoxic concentration: 58000 nM
Beside the measured number, compound 4's estimate is 1.7-fold (0.24 log units) above it; the range from low to high includes it.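

Within the data shown here, the first step in this set at the saturated chain carbon bound to a carbonyl carbon shows that, in this assay, hydrogen in place of 4-methylpiperazin-1-yl gives a 1.6-fold lower number from compound 1 to compound 4 (0.19 log units; within the scatter) and thus no change that can be told from the scatter. The earlier compounds shown here offered no pair to test this, and here a whole six-membered non-aromatic ring with 2 hetero atoms leaves without a step that stands out from repeated measurement, so this one pair gives no sign that the 4-methylpiperazin-1-yl group matters for how much compound the cells tolerate. Compound 4, like compound 1, gives an actual number and not a limit, while the other values shown remain limits of the assay: the limit of > 100000 nM in this assay, at which 2 of the 4 values shown sit.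

The compounds shown leave open whether other groups at this chain carbon, such as morpholine, a primary amine, a carboxylic acid or a longer chain, would also stay within the scatter of compound 1. They also leave open whether the same swap would give so small a step on a core carrying trifluoromethyl in place of the two chlorine atoms.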